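The source may hold more compounds than are shown below. What is called first, only, known or untested is meant among the compounds shown, and "the series" means these compounds.

In a functional assay on RAW264.7 cells (Mus musculus) for inhibition, read by Griess assay, with stated times of 2 h and 24 h (on this read-out higher numbers stand for weaker inhibition and lower numbers for stronger inhibition), compound 1 (`CCCn1cc(COc2cc(O)c3c(c2)O[C@H](c2ccc(OC)c(O)c2)CC3=O)nn1`) gives 9670 nM while compound 2 (`COc1ccc([C@@H]2CC(=O)c3c(O)cc(OCc4cn(C)nn4)cc3O2)cc1O`) gives 15200 nM and compound 3 (`COc1ccc([C@@H]2CC(=O)c3c(O)cc(OCc4cn(Cc5ccc(C)cc5)nn4)cc3O2)cc1O`) gives 16800 nM on this read-out. Compound 3 therefore stands within the scatter of both other compounds. The change to compound 4 (`COc1ccc([C@@H]2CC(=O)c3c(O)cc(OCc4cn(C5CCC5)nn4)cc3O2)cc1O`) puts cyclobutyl in place of 4-methylbenzyl on an aromatic nitrogen. Among the measured compounds shown here, three measured steps bear on it, each altering the group on that same nitrogen: one (a 1.6-fold higher number from compound 1 to compound 2 (0.20 log units; within the scatter)) and a second (a 1.7-fold higher number from compound 1 to compound 3 (0.24 log units; within the scatter)) and a third (a 1.1-fold higher number from compound 2 to compound 3 (0.04 log units; within the scatter)). All three lie within the scatter, so no step beyond the scatter is expected in this assay here. The estimated change is small (a 1.3-fold lower number from compound 3 to compound 4 (0.11 log units; within the scatter)). Compound 4 is expected at 13000 nM with an estimated range from 6500 nM to 26000 nM in this measurement.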

Compound 4, half-maximal inhibitory concentration: 15300 nM
Estimate against measurement, compound 4: 1.2-fold (0.07 log units) below; the measured number falls inside the stated range.
By their numbers in this assay, from the lowest: compounds 1, 2, 4 and 3 (each within the scatter of the next).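

In this assay, cyclobutyl, a four-membered non-aromatic ring of carbon only, stays within the scatter of all three earlier groups on the aromatic nitrogen: a 1.1-fold lower number from compound 3 to compound 4 (0.04 log units; within the scatter) against 4-methylbenzyl, a 1.0-fold higher number from compound 2 to compound 4 (0.00 log units; within the scatter) against methyl and a 1.6-fold higher number from compound 1 to compound 4 (0.20 log units; within the scatter) against propyl. The position thus tolerates this ring as well, and the four groups shown do not separate beyond the scatter. Nothing measured here explains this result. As far as these compounds go, whether an amine or a carboxylic acid on this nitrogen would move the number beyond the scatter remains open.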